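This account rests on a few compounds, and the source may have more. Where it says the series, first, only, none or still open, it means among the compounds named here.

The series is assayed in an assay on cells for agonist activity at ecdysone receptor (Bombyx mori), read by a luciferase reporter, with a stated time of 24 h; a lower number here means that less compound is needed, a higher number that more compound is needed for the effect. Compound 1, with the structure `COc1cccc(C(=O)NN(C(=O)c2ccccc2Cl)C(C)(C)C)c1`, gives 52.5 nM. Compound 2, with the structure `CN(NC(=O)c1ccccc1)C(=O)c1ccccc1`, has no number at all in this assay: it sits at the assay limit, > 100000 nM. That limit is where compound 2 stands among the values shown, as the limit of > 100000 nM in this assay, at which 1 of the 2 values shown sits, makes plain, so nothing about the size of any step can be read from compound 2 beyond the fact that a numbered value would have to lie on the lower side of it. Compound 3, with the structure `CC(C)CN(NC(=O)c1ccccc1)C(=O)c1ccccc1`, differs from compound 2 in a single place: isopropyl in place of hydrogen on a saturated chain carbon bound to an amide-type nitrogen, so that the chain on the nitrogen grows from methyl to isobutyl. Among the compounds with values here, since no measured step is available, the step is a matter of expectation only; compound 3 is expected to move toward lower values by an at least 12-fold lower number from compound 2 to compound 3 (1.09 log units; beyond the scatter), and its estimate is 8000 nM, within 600 nM to 100000 nM.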

Compound 3, half-maximal effective concentration: 2880 nM
Compound 3: middle estimate off by 2.8-fold (0.44 log units), on the high side, within the range that was stated.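

In this assay, within the data shown here, a single change at the amide-type nitrogen can now be read for the first time: with isopropyl in place of hydrogen on the saturated chain carbon, turning methyl into isobutyl, the result is an at least 34-fold lower number from compound 2 to compound 3 (1.54 log units; beyond the scatter). Among these compounds, the change in this chain alone is enough to take the series from a limit to a measured number, which the earlier compounds could not show. The true size of the step stays unknown, because compound 2 has only a limit and no number: the limit of > 100000 nM in this assay, at which 1 of the 3 values shown sits.

The compounds shown leave open whether chain length or branching matters here, which an unbranched butyl chain on the same nitrogen would help to separate. On these data alone, it also remains open how this position would respond to a cyclohexyl ring or an amine at the end of the chain.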